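This account rests on a few compounds, and the source may have more. Where it says the series, first, only, none or still open, it means among the compounds named here.

Measured so far:
Compound 1 `Cn1cnc2c(N3CCCCC3)nc(-c3ccccc3O)nc21`: in an assay on cells for displacement of a labelled ligand from adenosine receptor A1 (Homo sapiens), read by scintillation counting and radioligand binding, with a stated time of 60 min, tested at 10 uM (a lower number here means less inhibition, a higher number more inhibition at the concentration tested (going by the name of the read-out)), compound 1 gives 50.5%.
Compound 2 `CN1CCN(c2nc(-c3ccccc3O)nc3c2ncn3C)CC1`: in this assay compound 2 gives > 80%, which is a limit of the assay and not a number.

For the measured compounds named here, compound 1 therefore stands as the only plain number in this assay; the one other value shown is a limit (the limit of > 80% in this assay, at which 1 of the 2 values shown sits). Going by the values given here, the single measured step, a number at least 29.5 percentage points higher from compound 1 to compound 2 (beyond the scatter), comes from a change elsewhere on the shared core, where 4-methylpiperazin-1-yl stands in place of piperidin-1-yl.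

Compound 3 `Cn1cnc2c(N3CCCCC3)nc(-c3ccccc3Cl)nc21` has not yet been measured. It differs from compound 1 in one place: chloro in place of hydroxy on an aromatic carbon. Among the compounds with values here, no measured step touches this part of the molecule, so the step from compound 1 to compound 2 offers no guide to the size or direction of the change made here. With no comparison to lean on, compound 3 is expected to stay close to compound 1, and a number 0.5 percentage points lower from compound 1 to compound 3 (within the scatter) is the expected step, one that need not exceed the scatter. The estimate for compound 3 in this assay is 50%, expected to fall between 25% and 75%.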

Compound 3, a percentage reported as inhibition, at one concentration (the size of the read-out at that concentration, not a potency): 35.2%
Compound 3: middle estimate off by 14.8 percentage points, on the high side, and the stated range covers the measured number.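

In this assay, the change at this ring position gives a number 15.3 percentage points lower from compound 1 to compound 3 (beyond the scatter), which shows that the read-out responds to what sits on the 2-hydroxyphenyl ring and not only to the piperidin-1-yl part altered in the earlier step. The swap replaces hydroxy, with 1 hydrogen-bond donor and 1 hydrogen-bond acceptor, with chloro, which has neither, and compound 3 still gives 35.2%, so some inhibition at the tested concentration remains without the hydroxy group. These counts describe the change but do not explain it, and no measurement shown here says why the number falls.

The compounds shown leave open how other groups at this ring position would compare, such as an amino group, a methoxy group or a carboxylic acid. They also leave open how chloro in place of hydroxy would behave alongside the 4-methylpiperazin-1-yl group of compound 2, whose > 80% is a limit of the assay and not a number.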